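Adding a Methylsulfonyl Group to a Cytotoxicity-Limit Compound

A few compounds are considered here, and "the series" means these few. Any claim that something is new, unique, unknown or untested is made for them only; others in the source may bear on it.

Compound 1, `Cc1nn(-c2ccccc2)c2nc(-c3ccccc3)c(C#N)c(-c3ccccc3O)c12`, was tested in an ADME assay on BJ cells (Homo sapiens) for cytotoxicity, with a stated time of 72 h; on this read-out higher numbers stand for an effect only at larger amounts of compound and lower numbers for an effect already at smaller amounts. In this assay compound 1 gives only a limit, > 23000 nM, and not a number. Its companion compound 2, `CCc1ccc(-c2nc3c(c(C)nn3-c3ccccc3)c(-c3ccccc3Br)c2C#N)cc1`, which carries other substituents on the shared core, likewise gives only a limit, > 20000 nM. Both values therefore sit at the edge of what this assay can report, as shown by the limit of > 20000 nM in this assay, at which 1 of the 2 values shown sits, and (the limit of > 23000 nM in this assay, at which 1 of the 2 values shown sits), so no difference between them can be read, and neither compound can be placed above or below the other.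

The unmeasured compound 3, `Cc1nn(-c2ccccc2)c2nc(-c3ccc(S(C)(=O)=O)cc3)c(C#N)c(-c3ccccc3O)c12`, differs from compound 1 in one place: methylsulfonyl in place of hydrogen on an aromatic carbon. For the measured compounds named here, no measured pair in this set carries such a change, so there is no direct precedent for how this assay responds to it. The expectation is that the step from compound 1 to compound 3 stays within the usual scatter, with a step that the limit leaves unreadable from compound 1 to compound 3 as the expected shift. On that basis compound 3 is expected to give about 25000 nM, within a range from 10000 nM to 60000 nM, most likely reported again only as a limit.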

Compound 3, half-maximal effective concentration: > 20000 nM
Compound 3 ended at the assay's limit; the forecaster's own chance of this, stated with the estimate: 80%; the middle value is on the limit's open side.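

In this assay, for the compounds shown here, compound 1 and compound 3 both give only limits and not numbers, so no step between these two compounds can be read. The compounds shown leave open whether methylsulfonyl in place of hydrogen on an aromatic carbon shifts the result at all, and if so, in which direction and by how much.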